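This account rests on a few compounds, and the source may have more. Where it says the series, first, only, none or still open, it means among the compounds named here.

In a functional assay on MOLT-4 cells (Homo sapiens) for inhibition, read by sulforhodamine B assay, with a stated time of 48 h (on this read-out lower numbers stand for stronger inhibition of growth and higher numbers for weaker inhibition of growth), compound 1 `O=C(Nc1cccc(-n2cc(-c3ccncc3)c(-c3ccc(Cl)c(O)c3)n2)c1)Nc1cccc(C(F)(F)F)c1` gives 1920 nM. In this assay compound 2 `COc1cc(-c2nn(-c3cccc(NC(=O)Nc4ccc(Cl)c(Cl)c4)c3)cc2-c2ccncc2)ccc1Cl` gives 1100 nM.

Compound 2 and compound 1 differ from each other in two places at once, so no single step can be read between them; their two numbers lie within the scatter of each other, and neither stands apart. Compound 3 `O=C(Nc1cccc(-n2cc(-c3ccncc3)c(-c3ccc(Cl)c(O)c3)n2)c1)Nc1ccc(Cl)c(Cl)c1` differs from compound 2 in one place only: hydrogen in place of methyl on an oxygen on an aromatic ring. Compound 1 already carries that hydroxy group and gives 1920 nM; compound 2, carrying the methoxy, gives 1100 nM; the two sit close together. On that basis, for a 1.2-fold higher number from compound 2 to compound 3 (0.07 log units; within the scatter) the expectation is a step no larger than the scatter, in no particular direction. Compound 3 is therefore expected to give about 1300 nM, with a range from 500 nM to 3500 nM.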

Compound 3, concentration for 50% growth inhibition: 1380 nM
The estimate for compound 3 lay 1.1-fold (0.03 log units) below the measured number; the range from low to high includes it.
By their numbers in this assay, from the lowest: compounds 2, 3 and 1 (each within the scatter of the next).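

In this assay, methoxy and hydroxy can now be compared directly on the otherwise unchanged 4-chloro-3-methoxyphenyl position, where the exchange gives a 1.3-fold higher number from compound 2 to compound 3 (0.10 log units; within the scatter) and so leaves no readable difference from removing that methyl. Compound 3 also separates the second place in which compound 1 and compound 2 differ: putting 3,4-dichlorophenyl in place of 3-(trifluoromethyl)phenyl on the amide-type nitrogen gives a 1.4-fold lower number from compound 1 to compound 3 (0.14 log units; within the scatter) and again leaves no readable difference. No supporting measurement is available to explain either result.

Each exchange rests on a single pair of compounds, so neither says how other groups would behave in these two places. Going by these compounds, whether a longer chain on that oxygen, an amine in place of the hydroxy group, or a carboxylic acid on the phenyl ring attached to the amide-type nitrogen would move the number beyond the scatter remains open.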